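This account rests on a few compounds, and the source may have more. Where it says the series, first, only, none or still open, it means among the compounds named here.

Measured so far in an assay for inhibition of 6-phosphofructo-2-kinase/fructose-2,6-bisphosphatase 3 (Homo sapiens), read by ADP-Glo, with a stated time of 2 h; on this read-out lower numbers stand for stronger inhibition and higher numbers for weaker inhibition:
compound 1 `CN1CCC(CNS(=O)(=O)c2ccccc2Nc2cc(-c3ccc4ccn(C)c4c3)c3nccnc3c2)C1` gives 11 nM
compound 2 `CN(C)S(=O)(=O)c1ccccc1Nc1cc(-c2ccc3ccn(C)c3c2)c2nccnc2c1` gives 94 nM

Among the measured compounds shown here, compound 2 holds the higher of the two numbers; the only step available is an 8.5-fold higher number from compound 1 to compound 2 (0.93 log units; beyond the scatter). Compound 3 `CN1CCCC(NS(=O)(=O)c2ccccc2Nc2cc(-c3ccc4ccn(C)c4c3)c3nccnc3c2)C1` differs from compound 2 by (1-methylpiperidin-3-yl)amino in place of dimethylamino on a sulfonyl sulfur. This brings back a cyclic amine of the kind seen in compound 1, so the relevant comparison is an 8.5-fold higher number from compound 1 to compound 2 (0.93 log units; beyond the scatter) run backwards, and a step of roughly that size toward a lower number is expected. The step expected here is a 6.3-fold lower number from compound 2 to compound 3 (0.80 log units; beyond the scatter). Compound 3 is expected at 15 nM, range 5 nM to 50 nM.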

Compound 3, half-maximal inhibitory concentration: 59 nM
Estimate against measurement, compound 3: 3.9-fold (0.59 log units) below; the whole stated range lies below it.
By their numbers in this assay, from the lowest: compound 1; then compounds 3 and 2 (each within the scatter of the next).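

On the sulfonyl sulfur, (1-methylpiperidin-3-yl)amino and dimethylamino are not separated by this result (a 1.6-fold lower number from compound 2 to compound 3 (0.20 log units; within the scatter)), so a cyclic amine there does not by itself reproduce the number of compound 1. The exact group on the sulfonamide nitrogen counts, as 1-methylpiperidin-3-yl in place of (1-methylpyrrolidin-3-yl)methyl shows (a 5.4-fold higher number from compound 1 to compound 3 (0.73 log units; beyond the scatter)). Nothing on hand accounts for this difference.

Still open, on these data alone, is whether the methylene link or the ring size separates compound 1 from compound 3, since these two groups differ in both. A (1-methylpiperidin-3-yl)methyl group on the sulfonamide nitrogen would divide the two.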